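This account rests on a few compounds, and the source may have more. Where it says the series, first, only, none or still open, it means among the compounds named here.

Compound 1 `CC(C)=CCC/C(C)=C/CC/C(C)=C/CC[C@@H]1[C@@]2(C)CC/C(=N\OCc3cn(-c4c(Cl)cc([N+](=O)[O-])cc4Cl)nn3)C(C)(C)[C@@H]2CC[C@@]1(C)O` and compound 2 `COc1cc(OC)c(-n2cc(CO/N=C3\CC[C@]4(C)[C@@H](CC/C=C(\C)CC/C=C(\C)CCC=C(C)C)[C@](C)(O)CC[C@H]4C3(C)C)nn2)c(OC)c1` share one core and differ in a single spot: 2,4,6-trimethoxyphenyl in place of 2,6-dichloro-4-nitrophenyl on an aromatic nitrogen. In a functional assay on A549 cells (Homo sapiens) for cytotoxicity, read by MTT assay, with a stated time of 48 h (on this read-out lower numbers stand for stronger inhibition and higher numbers for weaker inhibition), compound 1 gives 11200 nM, while in this assay compound 2 gives 8120 nM, a step of a 1.4-fold lower number from compound 1 to compound 2 (0.14 log units; within the scatter). Compound 3 `CC(C)=CCC/C(C)=C/CC/C(C)=C/CC[C@@H]1[C@@]2(C)C/C(=C\c3ccc(OCc4cn(-c5c(Cl)cc([N+](=O)[O-])cc5Cl)nn4)cc3)C(=O)C(C)(C)[C@@H]2CC[C@@]1(C)O` is built on another core; the difference between the two cores is not broken down here. In this assay compound 3 gives 34700 nM, the highest of the three numbers, separated from compound 1 and from compound 2 by more than the scatter. Compound 4 `COc1cc(OC)c(-n2cc(COc3ccc(/C=C4\C[C@]5(C)[C@@H](CC/C=C(\C)CC/C=C(\C)CCC=C(C)C)[C@](C)(O)CC[C@H]5C(C)(C)C4=O)cc3)nn2)c(OC)c1` has not yet been measured. It differs from compound 3 by the same change, at the same place: 2,4,6-trimethoxyphenyl in place of 2,6-dichloro-4-nitrophenyl on an aromatic nitrogen. The step from compound 3 to compound 4 in this assay is expected to be a 1.3-fold lower number from compound 3 to compound 4 (0.13 log units; within the scatter), roughly matching the earlier one, because the step of a 1.4-fold lower number from compound 1 to compound 2 (0.14 log units; within the scatter) stayed within the scatter and nothing among these compounds suggests the change behaves otherwise on the second core. Compound 4 is therefore estimated at 26000 nM, with a likely range from 12000 nM to 55000 nM.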

Compound 4, half-maximal inhibitory concentration: 16100 nM
Compound 4: the middle estimate sits 1.6-fold (0.21 log units) above what was measured, and the stated range covers the measured number.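

In this assay, placing 2,4,6-trimethoxyphenyl where 2,6-dichloro-4-nitrophenyl stood on the second core gives a 2.2-fold lower number from compound 3 to compound 4 (0.33 log units; beyond the scatter), a modest step. Set beside the step on the first core, it does not differ from it by more than two such steps would be expected to: the same change on two cores in this assay, a 1.4-fold lower number (0.14 log units; within the scatter) from compound 1 to compound 2 and a 2.2-fold lower number (0.33 log units; beyond the scatter) from compound 3 to compound 4, 1.6-fold (0.19 log units) apart, within the scatter of two such steps. This means that, within these two pairs, the effect of the change on one core gave a usable rough guide to its effect on the other, but two pairs cannot show that it would carry over to further cores, and they do not explain why the numbers moved.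

As far as these compounds go, all four compounds carry a substituted phenyl ring on that aromatic nitrogen, so it remains open whether a different group there, such as a simple alkyl chain or a phenyl ring bearing an amine or a carboxylic acid, would behave alike on both cores. From the compounds shown here alone, whether the two cores would still respond alike to those groups also remains open.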